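The source may report more compounds than this note shows. Statements on the series, on what has been measured and on what is new or still open speak of the compounds shown alone.

Working notes on the series. Among the compounds with values here, the shared core carries a pyridine-type ring bearing ethoxy, methyl and a chloro or cyano group, and the three measured members differ only on that ring. Compound 1 `CCOc1nc(Cl)cc(NC(=O)NCc2cc(C)c(-c3cn(C)nc3C(F)(F)F)nn2)c1C` gives 8800 nM in a functional assay on CHO cells for antagonist activity at sphingosine 1-phosphate receptor 2 (Homo sapiens), read by fluorescence and calcium flux, with a stated time of 3 min; on this read-out higher numbers stand for weaker inhibition and lower numbers for stronger inhibition. Compound 2 `CCOc1nc(C#N)cc(NC(=O)NCc2cc(C)c(-c3cn(C)nc3C(F)(F)F)nn2)c1C` gives 7100 nM in this assay; the change cyano in place of chloro on an aromatic carbon made the step of a 1.2-fold lower number from compound 1 to compound 2 (0.09 log units; within the scatter). Compound 3 `CCOc1nc(C)cc(NC(=O)NCc2cc(C)c(-c3cn(C)nc3C(F)(F)F)nn2)c1Cl` gives 8700 nM in this assay; against compound 1 it shows the difference (3-chloro-2-ethoxy-6-methylpyridin-4-yl in place of 6-chloro-2-ethoxy-3-methylpyridin-4-yl on an amide-type nitrogen), with the step of a 1.0-fold lower number from compound 1 to compound 3 (0.00 log units; within the scatter). Compound 4 `CCOc1nc(C)cc(NC(=O)NCc2cc(C)c(-c3cn(C)nc3C(F)(F)F)nn2)c1C#N`, not yet measured, differs from compound 3 by cyano in place of chloro on an aromatic carbon. This is the same kind of change as that from compound 1 to compound 2, but the surroundings differ: in compound 2 the new group sits next to the ring nitrogen, meta to a large group and meta to an ethoxy group, whereas in compound 4 it sits ortho to a large group, ortho to an ethoxy group and two atoms from the ring nitrogen. Given the step of a 1.2-fold lower number from compound 1 to compound 2 (0.09 log units; within the scatter) and the value of compound 3 8700 nM, a step of similar size is expected, namely a 1.2-fold lower number from compound 3 to compound 4 (0.06 log units; within the scatter). Compound 4 is therefore estimated at 7500 nM in this assay, with a range from 3500 nM to 16000 nM.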

Compound 4, half-maximal inhibitory concentration: > 20000000 nM
Compound 4: a limit, no number; the forecaster's own chance of this, stated with the estimate: 5%; middle value at least 2600-fold (3.42 log units) from the limit.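

In this assay, cyano in place of chloro on an aromatic carbon gives an at least 2200-fold higher number from compound 3 to compound 4 (3.36 log units; beyond the scatter), so the change does not carry from the core of compound 1 to the core of compound 3: the same change on two cores in this assay, a 1.2-fold lower number (0.09 log units; within the scatter) from compound 1 to compound 2 and an at least 2200-fold higher number (3.36 log units; beyond the scatter) from compound 3 to compound 4, at least 2800-fold (3.45 log units) apart, beyond the scatter of two such steps

Compound 4 stands at > 20000000 nM, which is a limit of the assay and not a number, so the full size of this step stays unknown: the limit of > 20000000 nM in this assay, at which 1 of the 4 values shown sits.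

Two pairs do not show whether the place ortho to a large group and ortho to an ethoxy group accounts for the gap, or whether the result extends to any other core.

From the compounds shown here alone, it remains open how an amine or a carboxylic acid on that same aromatic carbon would read. Going by these compounds, it also remains open whether a longer chain in place of the ethoxy group would alter the step.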